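A few compounds are considered here, and "the series" means these few. Any claim that something is new, unique, unknown or untested is made for them only; others in the source may bear on it.

Going by the values given here, in a functional assay on C6 cells for antagonist activity at prostacyclin receptor (Homo sapiens), read by TR-FRET and cAMP accumulation, with stated times of 10 min and 40 min (on this read-out higher numbers stand for weaker inhibition and lower numbers for stronger inhibition), three compounds have numbers so far. Compound 1 `COc1cc(/C=C/C(=O)NCCn2c(C(F)(F)F)cc3ccccc32)cc(OC)c1OCCO` gives 95900 nM, compound 2 `Cc1cc2ccccc2n1CCNC(=O)/C=C/c1ccc(OCCCO)cc1` gives 210000 nM, and compound 3 `Cc1cc(/C=C/C(=O)NCCn2c(C)cc3ccccc32)cc(C)c1F` gives 22500 nM. Compound 2 therefore stands at the highest number of the three, that is, as the weakest inhibitor among them: its gap to compound 1 and its larger gap to compound 3 both lie beyond the usual scatter of this measurement.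

Compound 4 `Cc1cc2ccccc2n1CCNC(=O)/C=C/c1ccc(OCCO)cc1` has not been measured in this assay. It differs from compound 2 in one place: hydroxy in place of hydroxymethyl on a saturated chain carbon, two bonds along the chain from an oxygen on an aromatic ring. In plain terms, the chain hanging from the aromatic oxygen is shortened by one carbon while keeping its terminal hydroxy group.

Among the compounds with values here, no pair of measured compounds shows the effect of this exact change, so no step size is known here. Compound 1, which carries the shorter chain on a different core, gives 95900 nM, but its other differences from compound 2 prevent any direct reading. The step from compound 2 to compound 4 is expected to be small, a 1.4-fold lower number from compound 2 to compound 4 (0.15 log units; within the scatter), likely within the scatter. Compound 4 is expected to give about 150000 nM, with a range from 50000 nM to 450000 nM.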

Compound 4, antagonist equilibrium constant: 30000 nM
The estimate for compound 4 lay 5.0-fold (0.70 log units) above the measured number, outside the stated range (below it).
By their numbers in this assay, from the lowest: compounds 3 and 4 (each within the scatter of the next); then compound 1; then compound 2.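

In this assay, shortening 3-hydroxypropoxy to 2-hydroxyethoxy gives a 7.0-fold lower number from compound 2 to compound 4 (0.85 log units; beyond the scatter). Going by these compounds alone, the earlier compounds offered no pair differing in one place, so this is the first direct reading at this position, and it shows that removing 1 carbon from the chain on the aromatic oxygen strengthens inhibition, even with the terminal hydroxy group kept. Nothing at hand explains why the shorter chain does better.

On these data alone, it remains open whether a still shorter group such as methoxy would strengthen inhibition further, or whether an amine or a carboxylic acid at the chain end could replace the hydroxy group. It is also unknown whether the same shortening would have a similar effect when the rest of the molecule differs.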